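Three measured analogues and a bromophenyl newcomer

The source may report more compounds than this note shows. Statements on the series, on what has been measured and on what is new or still open speak of the compounds shown alone.

Of the compounds shown here, three built on one shared core have been tested in an ADME assay on WI-38 cells (Homo sapiens) for cytotoxicity, read by MTT assay, with a stated time of 72 h; a lower number here means a stronger inhibitor, a higher number a weaker inhibitor. Compound 1 `CN(C)CCn1cnnc1-c1cc(Oc2ccc(NC(=O)N/N=C/c3c[nH]c4ccccc34)cc2F)ccn1` gives 3620 nM. Compound 2 `CN(C)CCn1cnnc1-c1cc(Oc2ccc(NC(=O)N/N=C/c3cc(C(C)(C)C)cc(C(C)(C)C)c3O)cc2F)ccn1` gives 2350 nM. Compound 3 `CN(C)CCn1cnnc1-c1cc(Oc2ccc(NC(=O)N/N=C/c3ccccc3O[N+](=O)[O-])cc2F)ccn1` gives 6860 nM, the highest of the three numbers shown; its gap to compound 1 is within the scatter, while its gap to compound 2 lies beyond it. For the measured compounds named here, the only step between compounds differing in a single place is a 1.9-fold higher number from compound 1 to compound 3 (0.28 log units; within the scatter), so that exchange of the aryl group on the carbon with a double bond to nitrogen stayed within the scatter.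

Compound 4 `CN(C)CCn1cnnc1-c1cc(Oc2ccc(NC(=O)N/N=C/c3cccc(Br)c3)cc2F)ccn1` has not yet been measured. It differs from compound 3 by 3-bromophenyl in place of 2-(nitrooxy)phenyl on a carbon with a double bond to nitrogen. Going by the values given here, no measured step involves a 3-bromophenyl group, so the only guide is the earlier aryl exchange at the same position, which stayed within the scatter. Hence no step beyond the scatter is expected in this assay between compound 3 and compound 4. The estimated step is a 1.2-fold lower number from compound 3 to compound 4 (0.10 log units; within the scatter). Compound 4 is expected to give about 5500 nM, with a range from 2500 nM to 12000 nM.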

Compound 4, half-maximal inhibitory concentration: 4230 nM
Compound 4: middle estimate off by 1.3-fold (0.11 log units), on the high side, within the range that was stated.
By their numbers in this assay, from the lowest: compounds 2, 1, 4 and 3 (each within the scatter of the next, the first and the last beyond it).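

Replacing 2-(nitrooxy)phenyl with 3-bromophenyl on the carbon with a double bond to nitrogen gives a 1.6-fold lower number from compound 3 to compound 4 (0.21 log units; within the scatter) in this assay and replacing 1H-indol-3-yl with 3-bromophenyl there gives a 1.2-fold higher number from compound 1 to compound 4 (0.07 log units; within the scatter). For the compounds shown here, compounds 1, 3 and 4 therefore carry three different groups at this position with no step between them beyond the scatter, even though 3-bromophenyl has fewer heavy atoms than 2-(nitrooxy)phenyl and no hydrogen-bond acceptors; compound 2 still stands apart from compound 3, the one gap beyond the scatter. Nothing available here explains why these numbers fall where they do.

On these data alone, it remains open whether a group carrying an amine or a carboxylic acid at this position would produce a step beyond the scatter. As far as these compounds go, it is also open whether plain phenyl or 3-chlorophenyl would give a number close to that of compound 4.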